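Swapping the aryl on the sulfonyl of compound 3

The compounds below may be only part of what the source reports. "The series", "measured", "known", "first", "only" and "open" are said of these compounds alone.

Compound 1 `Cc1ccc2cccc(NS(=O)(=O)c3ccccc3[N+](=O)[O-])c2n1` gives > 90% in an assay on HUVEC cells for inhibition of transcription factor p65 (Homo sapiens); a lower number here means a smaller maximal response, a higher number a larger maximal response.
Compound 2 `COc1cc(NS(=O)(=O)c2ccc(C)cc2[N+](=O)[O-])c2ncccc2c1` gives > 90%.
Compound 3 `Cc1ccc2cccc(NS(=O)(=O)c3ccccc3N)c2n1` gives > 90%.

Each of these values is a limit of the assay, not a number. Compound 3 thus stands at the upper limit, where all three measured compounds sit (the limit of > 90% in this assay, at which 3 of the 3 values shown sit). Going by the values given here, the only measured step, a step that the two limits leave unreadable from compound 1 to compound 3, cannot be sized, since both of its ends are limits. Compound 4 `Cc1ccc2cccc(NS(=O)(=O)c3ccc(Br)s3)c2n1` differs from compound 3 by 5-bromothiophen-2-yl in place of 2-aminophenyl on a sulfonyl sulfur. Among the compounds with values here, no measured step covers a change of the aromatic group on the sulfonyl sulfur. With every measured compound at the limit, compound 4 is expected to reach it as well. The expected step that the limit leaves unreadable from compound 3 to compound 4 is thus none beyond the scatter. The estimate for compound 4 is 92%, between 70% and 100%.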

Compound 4, largest response reached (reported as efficacy), in percent of the reference or control that the assay uses: 75%
Compound 4: middle estimate off by 17 percentage points, on the high side, and the stated range covers the measured number.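

In this assay, the group on the sulfonyl sulfur turns out to matter: putting 5-bromothiophen-2-yl in place of 2-aminophenyl gives a number at least 15 percentage points lower from compound 3 to compound 4 (beyond the scatter). Compound 4 is the first compound here with a real number, which shows that a change at this place can bring the response down from the limit, where the others remain: the limit of > 90% in this assay, at which 3 of the 4 values shown sit.

The change replaces the ring and adds the bromine in one step, and the compounds shown do not separate the two. From the compounds shown here alone, whether a plain thiophen-2-yl or a 5-chlorothiophen-2-yl group would give a similar number stays open.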